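Replacing naphthalen-1-yl with pyridin-3-yl in compound 2

The compounds below may be only part of what the source reports. "The series", "measured", "known", "first", "only" and "open" are said of these compounds alone.

In a functional assay (strain AB) with Danio rerio as the target, read by microscopy, with a stated time of 1 h (a lower number here means that less compound is needed, a higher number that more compound is needed for the effect), compound 1 (`CC(C)[N+]1(C)CCc2c(sc(NC(=O)Nc3ccc(Cl)cc3)c2C(N)=O)C1`) gives 960 nM and compound 3 (`CCN1CCc2c(sc(NC(=O)Nc3cccc(C#N)c3)c2C(N)=O)C1`) gives 10300 nM while compound 2 (`NC(=O)c1c(NC(=O)Nc2ccc(Cl)cc2)sc2c1CCN(CCCNC(=O)CCc1cccc3ccccc13)C2`) gives 110 nM as the lowest of the three numbers. Compound 2 stands apart from both of the others by more than the usual scatter.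

Compound 4 (`NC(=O)c1c(NC(=O)Nc2ccc(Cl)cc2)sc2c1CCN(CCCNC(=O)CCc1cccnc1)C2`) is compound 2 with pyridin-3-yl in place of naphthalen-1-yl on a saturated chain carbon, two bonds along the chain from a carbonyl carbon. Among the compounds with values here, no measured pair shows this change alone, so any forecast is loose. Within the data shown here, compound 2 at 110 nM is the only measured compound carrying naphthalen-1-yl, and compound 1 at 960 nM and compound 3 at 10300 nM both lie higher while also differing from it elsewhere.

An upward step beyond the scatter is therefore expected, estimated at a 6.4-fold higher number from compound 2 to compound 4 (0.80 log units; beyond the scatter) toward the higher number. For compound 4 the estimated value is 700 nM with an expected range of 180 nM to 3500 nM in this assay once it is measured.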

Compound 4, half-maximal effective concentration: 470 nM
For compound 4 the middle estimate is 1.5-fold (0.17 log units) above the measured one; the measured number falls inside the stated range.
By their numbers in this assay, from the lowest: compound 2; then compound 4; then compound 1; then compound 3.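

In this assay, within the data shown here, pyridin-3-yl in place of naphthalen-1-yl on a saturated chain carbon, two bonds along the chain from a carbonyl carbon, gives a 4.3-fold higher number from compound 2 to compound 4 (0.63 log units; beyond the scatter) and is the first single-place comparison in this set. It shows that the group at the end of this chain affects the number, with a step beyond the usual scatter. It also shows that compound 4 still gives 470 nM with one six-membered aromatic ring in place of two.

The change alters the ring count and brings in a ring nitrogen at once, so phenyl would be needed to separate the two. Also open, as far as these compounds go, is how a morpholine, a carboxylic acid or a longer chain would read at this position, and nothing available accounts for the step.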